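A few compounds are considered here, and "the series" means these few. Any claim that something is new, unique, unknown or untested is made for them only; others in the source may bear on it.

Compound 1 `Cc1cc(C(=O)Nc2ccccc2)nn1Cc1cc(Cl)ccc1OCc1ccccc1`: 39.8 nM
Compound 2 `Cc1cc(C(=O)NCc2ccccn2)nn1Cc1cc(Cl)ccc1OCc1ccccc1`: 25.1 nM
Compound 3 `Cc1cc(NC(=O)CC(C)(C)C)nn1Cc1cc(Cl)ccc1OCc1ccccc1`: 10 nM

In an assay on CHO-K1 cells for displacement of a labelled ligand from prostaglandin E2 receptor EP1 subtype (Homo sapiens) (a lower number here means a stronger inhibitor, a higher number a weaker inhibitor), compound 1 gives 39.8 nM. Only its step to compound 3 is beyond the scatter, a 4.0-fold lower number from compound 1 to compound 3 (0.60 log units; beyond the scatter); the step of a 1.6-fold lower number from compound 1 to compound 2 (0.20 log units; within the scatter) is within it. Compound 4 `Cc1cc(NC(=O)c2ccccc2)nn1Cc1cc(Cl)ccc1OCc1ccccc1` keeps every atom of compound 1 but joins them differently: benzamido in place of phenylcarbamoyl on an aromatic carbon. Among the measured compounds shown here, no measured pair shows exactly this change. The nearest is a 4.0-fold lower number from compound 1 to compound 3 (0.60 log units; beyond the scatter), where the amide is also turned around but a neopentyl chain replaces the phenyl, and a 2.5-fold lower number from compound 2 to compound 3 (0.40 log units; beyond the scatter) points the same way. A modest lowering of the number is therefore expected, a 2.0-fold lower number from compound 1 to compound 4 (0.30 log units; within the scatter). Compound 4 is estimated at 20 nM, with a range from 8 nM to 50 nM.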

Compound 4, half-maximal inhibitory concentration: 15.9 nM
Compound 4: middle estimate off by 1.3-fold (0.10 log units), on the high side; the measured number falls inside the stated range.
By their numbers in this assay, from the lowest: compounds 3, 4, 2 and 1 (each within the scatter of the next, the first and the last beyond it).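

Reversing the amide in this assay while keeping the phenyl and every atom count is enough to give a change beyond the scatter (a 2.5-fold lower number from compound 1 to compound 4 (0.40 log units; beyond the scatter)). The neopentyl chain is therefore not needed for this effect: phenyl on the same reversed amide stays within the scatter (a 1.6-fold higher number from compound 3 to compound 4 (0.20 log units; within the scatter)), as does the comparison with the pyridinylmethyl amide (a 1.6-fold lower number from compound 2 to compound 4 (0.20 log units; within the scatter)). No measurement here explains the effect of the amide's direction. Still open, from the compounds shown here alone, is how a urea or sulfonamide link would compare at this position. A carboxylic acid or an amine on the benzamido phenyl is equally untested here.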